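Chloro in Place of Hydrogen on a Shared Core

The source may report more compounds than this note shows. Statements on the series, on what has been measured and on what is new or still open speak of the compounds shown alone.

Compound 1 `COC(OC)C1OC(C)(C)OC1Cc1cnc2ccccc2n1` is assessed in a functional assay on EC9706 cells (Homo sapiens) for cytotoxicity, read by MTT assay, with a stated time of 48 h; a higher number here means a weaker inhibitor, a lower number a stronger inhibitor. In this assay compound 1 gives > 100 ug/mL, which is a limit of the assay rather than a number (the limit of > 100 ug/mL in this assay, at which 1 of the 2 values shown sits). Compound 2 `COC(OC)C1OC(C)(C)OC1Cc1cnc2ccc([N+](=O)[O-])cc2n1`, carrying a nitro group, gives 69.2 ug/mL in this assay. The step of an at least 1.4-fold lower number from compound 1 to compound 2 (0.15 log units; that floor lies within the scatter) is the only measured one that bears on the change to compound 3 `COC(OC)C1OC(C)(C)OC1Cc1cnc2cc(Cl)ccc2n1`, where (chloro in place of hydrogen on an aromatic carbon). A modest shift in the same direction, or none beyond the scatter, is therefore expected, amounting to an estimated step of an at least 1.2-fold lower number from compound 1 to compound 3 (0.09 log units; that floor lies within the scatter). Compound 3 is expected to give about 80 ug/mL, in the range 40 ug/mL to 150 ug/mL.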

Compound 3, half-maximal inhibitory concentration: 30.5 ug/mL
Estimate against measurement, compound 3: 2.6-fold (0.42 log units) above; measured number below the stated range.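

On the shared core, chloro in place of hydrogen on this aromatic carbon gives a change that clears the usual scatter in this assay: an at least 3.2-fold lower number from compound 1 to compound 3 (0.51 log units; beyond the scatter). The earlier step, an at least 1.4-fold lower number from compound 1 to compound 2 (0.15 log units; that floor lies within the scatter), could not show a change of that kind. The size of the new step is only a floor because compound 1 gives a limit of the assay, not a number: the limit of > 100 ug/mL in this assay, at which 1 of the 3 values shown sits.

On these data alone, whether bromo or an amine on the same carbon would go as far stays open. So does how chloro would behave on the other carbons of that ring.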